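Replacing Chloro on the Urea Aryl Tail of Compound 3

This account rests on a few compounds, and the source may have more. Where it says the series, first, only, none or still open, it means among the compounds named here.

Measured so far in a functional assay on HCT-116 cells (Homo sapiens) for inhibition, read by MTT assay, with a stated time of 2 days, tested at 100 uM; a higher number here means more inhibition of growth at the concentration tested, a lower number less inhibition of growth:
compound 1 `CNC(=O)c1cc(Oc2ccc3nc(NC(=O)Nc4ccc(Cl)cc4Cl)sc3c2)ccn1`, 93.6%
compound 2 `CNC(=O)c1cc(Oc2ccc3nc(NC(=O)c4ccc(Cl)cc4)sc3c2)ccn1`, 80.5%
compound 3 `CNC(=O)c1cc(Oc2ccc3nc(NC(=O)Nc4ccc(Cl)cc4)sc3c2)ccn1`, 85.2%

Compound 3 stands second highest of the three numbers, but its distances to both neighbours are within the scatter: a number 4.7 percentage points higher from compound 2 to compound 3 (within the scatter) and, in the other direction, a number 8.4 percentage points lower from compound 1 to compound 3 (within the scatter). For the measured compounds named here, only one step among the measured compounds lies beyond the scatter, a number 13.1 percentage points lower from compound 1 to compound 2 (beyond the scatter), which combines two changes at once.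

Compound 4 `CNC(=O)c1cc(Oc2ccc3nc(NC(=O)Nc4ccc(C5CCN(C(C)C)CC5)cc4)sc3c2)ccn1` differs from compound 3 in one place: 1-isopropylpiperidin-4-yl in place of chloro on an aromatic carbon. The step that bears most directly on this is the removal of the same chloro, a number 8.4 percentage points lower from compound 1 to compound 3 (within the scatter), which stayed within the scatter. Going by the values given here, no measured step puts a large group at this position, so there is no precedent for the entering group itself. On that basis the step is expected to be small, with no clear direction beyond the scatter: a number 3.2 percentage points lower from compound 3 to compound 4 (within the scatter). Compound 4 is therefore estimated at 82%, within a range of 58% to 97%.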

Compound 4, percent growth inhibition at one concentration: 95.5%
The estimate for compound 4 lay 13.5 percentage points below the measured number, within the range that was stated.
By their numbers in this assay, from the lowest: compounds 2, 3, 1 and 4 (each within the scatter of the next, the first and the last beyond it).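

In this assay, a number 10.3 percentage points higher from compound 3 to compound 4 (beyond the scatter), so the place para to a large group accepts 1-isopropylpiperidin-4-yl, with its six-membered non-aromatic ring, in place of a single chloro, and growth inhibition is not lost. For the compounds shown here, this is the first step beyond the scatter that changes one substituent on this aryl ring, whereas a number 8.4 percentage points lower from compound 1 to compound 3 (within the scatter) did not pass it. The earlier compounds shown here carried only chloro or hydrogen on this ring, so they could not show that a group of this size is accepted here. Nothing shown accounts for the rise.

As far as these compounds go, whether the step comes from the ring or from its nitrogen stays open. A cyclohexyl group, or a piperidine with hydrogen or methyl on its nitrogen, at this place would separate the two.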